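The source may report more compounds than this note shows. Statements on the series, on what has been measured and on what is new or still open speak of the compounds shown alone.

Measured so far in a physicochemical assay for solubility, at pH 7.4; a higher number here means a more soluble compound, a lower number a less soluble compound:

- compound 1, `Cc1cc(NC(=O)Nc2ccc(Cl)c(Cl)c2)c2ccccc2n1`: 300 nM
- compound 2, `COc1ccc(NC(=O)Nc2cc(C)nc3ccccc23)cc1Cl`: 400 nM
- compound 3, `CSc1ccccc1NC(=O)Nc1cc(C)nc2ccccc12`: 21000 nM

Compound 1 gives the lowest of the three numbers in this assay. Compound 2 sits nearest; the step of a 1.3-fold higher number from compound 1 to compound 2 (0.12 log units; within the scatter) lies within the scatter, so the two cannot be ranked against each other. Compound 3 stands furthest off, with a number well beyond the scatter above compound 1, but it differs from compound 1 in more than one place, so no single change can be read from that gap.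

Compound 4, `Cc1cc(NC(=O)Nc2ccc(Cl)cc2)c2ccccc2n1`, is not yet measured. It differs from compound 1 as follows: hydrogen in place of chloro on an aromatic carbon. The leaving chloro sits ortho to the remaining chloro group and meta to a large group.

Among the compounds with values here, no measured step removes a chloro outright; the only single-change step available, from compound 1 to compound 2, swaps one group for another on the same carbon and stays within the scatter. On that basis the expected step of a 1.8-fold higher number from compound 1 to compound 4 (0.26 log units; within the scatter) is small, with a lean towards a higher number, and could well fall inside the scatter. Compound 4 is therefore estimated at 550 nM, in the range 200 nM to 1500 nM.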

Compound 4, solubility: 1400 nM
Compound 4: the middle estimate sits 2.5-fold (0.41 log units) below what was measured; measured number inside the range.
By their numbers in this assay, from the lowest: compounds 1 and 2 (each within the scatter of the next); then compound 4; then compound 3.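

Hydrogen in place of chloro on this aromatic carbon, ortho to a chloro group and meta to a large group, gives in this assay the step of a 4.7-fold higher number from compound 1 to compound 4 (0.67 log units; beyond the scatter) and so provides the first single change in the series that lies beyond the scatter, though a modest one. The earlier step of a 1.3-fold higher number from compound 1 to compound 2 (0.12 log units; within the scatter) brought in methoxy at the other chloro group of compound 1 and stayed within the scatter, so it gave no reading for this carbon. No measurement at hand accounts for the size of the new step.

Open, from the compounds shown here alone, is whether a different group on this carbon, such as fluoro, an amine or a carboxylic acid, would give a number closer to that of compound 4 or to that of compound 1. Also open, going by these compounds, is what taking away only the other chloro group would give, and whether hydrogen in place of chloro at this carbon gives a step of similar size when other groups stand elsewhere on the shared core.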